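Swapping One Ring Nitrogen In at the Sulfonyl

The compounds below may be only part of what the source reports. "The series", "measured", "known", "first", "only" and "open" are said of these compounds alone.

Of the compounds shown here, three have been measured so far in a functional assay on BXPC-3 cells (Homo sapiens) for inhibition, read by MTT assay, with a stated time of 7 days; a higher number here means a weaker inhibitor, a lower number a stronger inhibitor. Compound 1 `CCN(CC)S(=O)(=O)c1ccc(S(=O)(=O)N2CCC[C@@H](C(=O)N3CCC(c4nc(C(C)C)no4)CC3)C2)cc1` gives 300 nM, compound 2 `CCN(CC)S(=O)(=O)c1ccc(S(=O)(=O)N2CCC[C@@H](C(=O)NC3COC3)C2)cc1` gives 13800 nM, and compound 3 `CCOC(=O)[C@@H]1CCCN(S(=O)(=O)c2ccc(S(=O)(=O)N3CCCCC3)cc2)C1` gives 3300 nM. Among these three numbers compound 3 holds the second highest place. Its value lies nearer to compound 2, which gives 13800 nM, than to compound 1, which gives 300 nM, and both of these gaps fall beyond the scatter of repeated measurement.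

Compound 4 `CCOC(=O)[C@@H]1CCCN(S(=O)(=O)c2ccc(S(=O)(=O)N3CCNCC3)cc2)C1` is the next compound to be tested. It differs from compound 3 in a single place: piperazin-1-yl in place of piperidin-1-yl on a sulfonyl sulfur. Among the measured compounds shown here, no pair of measured compounds shows this same change, so its effect has to be estimated without a direct precedent. The expectation is a modest step in this assay, most likely toward a higher number and not far beyond the scatter, expressed as a 1.7-fold higher number from compound 3 to compound 4 (0.22 log units; within the scatter). Compound 4 is therefore expected to give about 5500 nM, with a plausible range from 1500 nM to 20000 nM.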

Compound 4, half-maximal inhibitory concentration: > 30000 nM
Compound 4: a limit, no number; the forecaster's own chance of this, stated with the estimate: 10%; middle value at least 5.4-fold (0.73 log units) away from the limit.
By their numbers in this assay, from the lowest: compound 1; then compound 3; then compound 2. At a limit, above all of these: compound 4.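

On the sulfonyl sulfur, whose other neighbour is an aromatic carbon, replacing piperidin-1-yl with piperazin-1-yl changes one ring atom to nitrogen, yet in this assay it gives an at least 9.0-fold higher number from compound 3 to compound 4 (0.95 log units; beyond the scatter). Among the compounds shown here, the ring keeps its size and its count of heavy atoms, so this position, which no earlier pair could test, does not tolerate every ring of that size. Compound 4 reads as a limit and not a number: the limit of > 30000 nM in this assay, at which 1 of the 4 values shown sits.

The compounds shown leave open whether the added hydrogen-bond donor or the ring nitrogen itself accounts for this step. A piperazine carrying a methyl group on its second nitrogen, or a morpholine ring with an oxygen in that place, would separate those two readings and show whether any of the activity of compound 3 can be kept.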